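The compounds below may be only part of what the source reports. "The series", "measured", "known", "first", "only" and "open" are said of these compounds alone.

Measured in a functional assay on V79 cells (Cricetulus griseus) for cytotoxicity, read by colony formation; a lower number here means a stronger inhibitor, a higher number a weaker inhibitor:
Compound 1 `CNCC1(C)CCN(c2c(F)cc3c(=O)c(C(=O)O)cn(C4CC4)c3c2C(F)(F)F)C1`: 230 ug/mL
Compound 2 `CC1(N)CCN(c2c(F)cc3c(=O)c(C(=O)O)cn(C4CC4)c3c2C(F)(F)F)C1`: 110 ug/mL

Of these two numbers, compound 2 has the lower, at 110 ug/mL. The next structure is compound 3 `CC1CN(c2c(F)cc3c(=O)c(C(=O)O)cn(C4CC4)c3c2C(F)(F)F)CCN1`, in which 3-methylpiperazin-1-yl takes the place of 3-amino-3-methylpyrrolidin-1-yl on an aromatic carbon, ortho to a fluoro group and ortho to a trifluoromethyl group: 3-methylpiperazin-1-yl in place of 3-amino-3-methylpyrrolidin-1-yl on an aromatic carbon. The two have the same atoms, joined differently.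

For the measured compounds named here, only one measured step bears on this change, and only loosely. It is a 2.1-fold lower number from compound 1 to compound 2 (0.32 log units; beyond the scatter), a modest step in which amino replaces (methylamino)methyl on a saturated ring carbon. Going by the values given here, that step leaves the five-membered ring in place, so no measurement yet covers a swap to a six-membered ring. Given the size of a 2.1-fold lower number from compound 1 to compound 2 (0.32 log units; beyond the scatter), a change of similar size at most is expected, with a slight lean towards a higher number and no clear step beyond the scatter. The expected step is a 1.4-fold higher number from compound 2 to compound 3 (0.13 log units; within the scatter). The estimate for compound 3 is 150 ug/mL, with an expected range of 65 ug/mL to 340 ug/mL.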

Compound 3, half-maximal inhibitory concentration: 220 ug/mL
The estimate for compound 3 lay 1.5-fold (0.17 log units) below the measured number; measured number inside the range.
By their numbers in this assay, from the lowest: compounds 2, 3 and 1 (each within the scatter of the next, the first and the last beyond it).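

In this assay, the exchange at this aromatic carbon, ortho to a fluoro group and ortho to a trifluoromethyl group, gives a 2.0-fold higher number from compound 2 to compound 3 (0.30 log units; within the scatter). The entering 3-methylpiperazin-1-yl has the same heavy atoms as the 3-amino-3-methylpyrrolidin-1-yl it replaces, so this pair shows that a six-membered ring with two hetero atoms can stand here in place of a five-membered ring with one, with no step beyond the scatter; the comparison with the larger group gives a 1.0-fold lower number from compound 1 to compound 3 (0.02 log units; within the scatter), so compound 3 cannot be separated from either compound 1 or compound 2, even though those two are separated from each other. Nothing available explains these numbers.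

The compounds shown leave open what a piperazin-1-yl group without its methyl, or a morpholin-4-yl group with an oxygen in place of the ring amine, would give at this carbon. They also leave open whether the same small steps would hold in this assay with a methoxy group or a hydrogen in place of the trifluoromethyl group.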